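Removing the methyl on compound 2: working notes

The compounds below may be only part of what the source reports. "The series", "measured", "known", "first", "only" and "open" are said of these compounds alone.

Measured so far in a functional assay on PC-3 cells (Homo sapiens) for inhibition, read by sulforhodamine B assay, with a stated time of 48 h; on this read-out higher numbers stand for weaker inhibition of growth and lower numbers for stronger inhibition of growth:
compound 1 `O=C(Nc1cccc(-n2cc(-c3ccncc3)c(-c3ccc(Cl)c(O)c3)n2)c1)Nc1cccc(C(F)(F)F)c1` gives 22500 nM
compound 2 `COc1cc(-c2nn(-c3cccc(NC(=O)Nc4cc(C(F)(F)F)cc(C(F)(F)F)c4)c3)cc2-c2ccncc2)ccc1Cl` gives 2070 nM
compound 3 `COc1cc(-c2nn(-c3cccc(NC(=O)Nc4cccc(C(F)(F)F)c4)c3)cc2-c2ccncc2)ccc1Cl` gives 2510 nM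

Compound 2 holds the lowest of the three numbers, though compound 3 sits within the scatter of it; compound 1 lies furthest away. Compound 4 `O=C(Nc1cccc(-n2cc(-c3ccncc3)c(-c3ccc(Cl)c(O)c3)n2)c1)Nc1cc(C(F)(F)F)cc(C(F)(F)F)c1` differs from compound 2 by hydrogen in place of methyl on an oxygen on an aromatic ring. The only step of this kind in the set is the reverse, a 9.0-fold lower number from compound 1 to compound 3 (0.95 log units; beyond the scatter), while a 1.2-fold higher number from compound 2 to compound 3 (0.08 log units; within the scatter) shows the second trifluoromethyl hardly matters. The corresponding step from compound 2 to compound 4 is therefore expected to raise the number, roughly an 8.7-fold higher number from compound 2 to compound 4 (0.94 log units; beyond the scatter). Compound 4 is estimated at 18000 nM in this assay, range 6000 nM to 45000 nM.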

Compound 4, concentration for total growth inhibition: 4370 nM
Compound 4: middle estimate off by 4.1-fold (0.61 log units), on the high side, outside the stated range (below it).
By their numbers in this assay, from the lowest: compounds 2, 3 and 4 (each within the scatter of the next, the first and the last beyond it); then compound 1.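

In this assay, hydrogen in place of methyl on this oxygen still raises the number when the second trifluoromethyl is present, with a 2.1-fold higher number from compound 2 to compound 4 (0.32 log units; beyond the scatter), but the size of the change differs between the two pairs: the same change on two cores in this assay, a 9.0-fold lower number (0.95 log units; beyond the scatter) from compound 1 to compound 3 and a 2.1-fold lower number (0.32 log units; beyond the scatter) from compound 4 to compound 2, 4.2-fold (0.63 log units) apart, beyond the scatter of two such steps. The second trifluoromethyl, which made no difference beyond the scatter among the methoxy compounds, does count among the hydroxy compounds, with a 5.1-fold lower number from compound 1 to compound 4 (0.71 log units; beyond the scatter): the same change on two cores in this assay, a 1.2-fold higher number (0.08 log units; within the scatter) from compound 2 to compound 3 and a 5.1-fold higher number (0.71 log units; beyond the scatter) from compound 4 to compound 1, 4.2-fold (0.63 log units) apart, beyond the scatter of two such steps. The two changes therefore do not add independently across these four compounds.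

Open, from the compounds shown here alone, is how an ethyl on this oxygen, or an amine in place of the methoxy, would compare. This interplay also rests on a single set of four compounds.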